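The source may hold more compounds than are shown below. What is called first, only, known or untested is meant among the compounds shown, and "the series" means these compounds.

The three measured compounds share one core and differ only in the group carried on an amine nitrogen in a ring. Compound 1 `CCN1CCN(C(=S)SCC(=O)Nc2cccc(NC(=O)c3ccccn3)c2)CC1` carries an ethyl group there, and in a functional assay on A549 cells (Homo sapiens) for antiproliferative activity, read by MTT assay, with a stated time of 48 h (a lower number here means a stronger inhibitor, a higher number a weaker inhibitor), compound 1 gives 3720 nM. Compound 2 `C=CCN1CCN(C(=S)SCC(=O)Nc2cccc(NC(=O)c3ccccn3)c2)CC1` carries an allyl group, and in this assay compound 2 gives 210 nM. Compound 3 `CC(C)(C)OC(=O)N1CCN(C(=S)SCC(=O)Nc2cccc(NC(=O)c3ccccn3)c2)CC1` carries a tert-butoxycarbonyl group, and in this assay compound 3 gives 180 nM. Compound 3 has the lowest of the three numbers, but it stands close to compound 2, as a 1.2-fold lower number from compound 2 to compound 3 (0.07 log units; within the scatter) shows, while the large gap is to compound 1, shown by a 21-fold lower number from compound 1 to compound 3 (1.32 log units; beyond the scatter) and likewise by an 18-fold lower number from compound 1 to compound 2 (1.25 log units; beyond the scatter).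

Compound 4 `O=C(CSC(=S)N1CCN(c2ccccc2)CC1)Nc1cccc(NC(=O)c2ccccn2)c1` is not yet measured. It differs from compound 3 in one place: phenyl in place of tert-butoxycarbonyl on an amine nitrogen in a ring. Going by the values given here, the steps that bear on it are those that change the group on this same amine nitrogen in a ring. They show that this position can move the number a great deal, as with a 21-fold lower number from compound 1 to compound 3 (1.32 log units; beyond the scatter), or hardly at all, as with a 1.2-fold lower number from compound 2 to compound 3 (0.07 log units; within the scatter). A phenyl group has not been tried in this series, so neither outcome can be ruled out, and the expected step is a 2.5-fold higher number from compound 3 to compound 4 (0.40 log units; beyond the scatter), with wide uncertainty. For compound 4 the estimate in this assay is 450 nM, with a range from 120 nM to 3000 nM.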

Compound 4, half-maximal inhibitory concentration: 530 nM
Beside the measured number, compound 4's estimate is 1.2-fold (0.07 log units) below it, and the stated range covers the measured number.
By their numbers in this assay, from the lowest: compounds 3 and 2 (each within the scatter of the next); then compound 4; then compound 1.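

Going by these compounds alone, with a phenyl group on this amine nitrogen, the number falls in a middle range that the earlier compounds did not occupy, since they had formed only a close pair and one distant compound: a 7.0-fold lower number from compound 1 to compound 4 (0.85 log units; beyond the scatter), but also a 2.5-fold higher number from compound 2 to compound 4 (0.40 log units; beyond the scatter) and a 2.9-fold higher number from compound 3 to compound 4 (0.47 log units; beyond the scatter). The phenyl group therefore shows that a six-membered aromatic ring of carbon only, with no hydrogen-bond acceptors, can sit at this position and give a lower number than the ethyl group, without matching the allyl or tert-butoxycarbonyl groups in this assay. There is no evidence at hand to explain why the phenyl group falls in this middle range.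

The compounds shown leave open whether a benzyl group, or a phenyl ring carrying a chlorine or a methoxy group, would move the number toward that of compound 2 and compound 3 or toward that of compound 1. They also leave open how an unsubstituted ring nitrogen, or a simple acetyl group on it, would compare with the tert-butoxycarbonyl group of compound 3.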